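The source may hold more compounds than are shown below. What is called first, only, known or untested is meant among the compounds shown, and "the series" means these compounds.

Measured in a functional assay on QGY-7703 cells (Homo sapiens) for cytotoxicity, read by MTT assay, with a stated time of 24 h; a higher number here means a weaker inhibitor, a lower number a stronger inhibitor:
- compound 1 `COc1cc(/C=C2\CN(S(=O)(=O)c3ccc(F)cc3)C/C(=C\c3cc(OC)c(OC)c(OC)c3)C2=O)cc(OC)c1OC`: 2220 nM
- compound 2 `O=C1/C(=C/c2cccc([N+](=O)[O-])c2)CN(S(=O)(=O)c2ccc(F)cc2)C/C1=C\c1ccccc1F`: 14900 nM
- compound 3 `COc1cc(/C=C2\CN(S(=O)(=O)c3ccc(F)cc3)C/C(=C\c3ccccc3F)C2=O)cc(OC)c1OC`: 13300 nM

In this assay, compound 3 lies within the scatter of compound 2, so these two cannot be told apart. Compound 1 stands clearly apart from compound 3, and the data show a 6.0-fold higher number from compound 1 to compound 3 (0.78 log units; beyond the scatter). That step puts 2-fluorophenyl in place of 3,4,5-trimethoxyphenyl.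

The compound in question is compound 4 `COc1cc(/C=C2\CN(S(=O)(=O)c3ccc(F)cc3)C/C(=C\c3cccc([N+](=O)[O-])c3)C2=O)cc(OC)c1OC`, which has 3-nitrophenyl in place of 2-fluorophenyl on a double-bonded chain carbon bound to a double-bonded ring carbon.

Among the measured compounds shown here, two measured steps bear on this. Swapping 3-nitrophenyl for 3,4,5-trimethoxyphenyl, with 2-fluorophenyl as the partner group, gave a 1.1-fold lower number from compound 2 to compound 3 (0.05 log units; within the scatter). If that exchange also made little difference here, compound 4 would be expected to fall near compound 1 at 2220 nM. However, no measured compound pairs 3-nitrophenyl with 3,4,5-trimethoxyphenyl, so that reading is untested, and a result near compound 3 remains possible.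

A partial move towards the lower number is therefore expected, smaller than the step from compound 1 to compound 3. The expected step is a 2.8-fold lower number from compound 3 to compound 4 (0.44 log units; beyond the scatter).

For compound 4 the estimate is 4800 nM, with an expected range from 1700 nM to 13500 nM.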

Compound 4, half-maximal inhibitory concentration: 3270 nM
Beside the measured number, compound 4's estimate is 1.5-fold (0.17 log units) above it; low and high end bracket the measured number.
By their numbers in this assay, from the lowest: compounds 1 and 4 (each within the scatter of the next); then compounds 3 and 2 (each within the scatter of the next).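

In this assay, with 3,4,5-trimethoxyphenyl held as the partner group, the position on a double-bonded chain carbon bound to a double-bonded ring carbon clearly responds to the swap of 2-fluorophenyl for 3-nitrophenyl, giving a 4.1-fold lower number from compound 3 to compound 4 (0.61 log units; beyond the scatter). The new compound also shows that 3-nitrophenyl and 3,4,5-trimethoxyphenyl cannot be told apart with a second partner group, a 1.5-fold higher number from compound 1 to compound 4 (0.17 log units; within the scatter), so the match first seen with 2-fluorophenyl as partner carries over to this core: the same change on two cores in this assay, a 1.1-fold lower number (0.05 log units; within the scatter) from compound 2 to compound 3 and a 1.5-fold lower number (0.17 log units; within the scatter) from compound 4 to compound 1, 1.3-fold (0.12 log units) apart, within the scatter of two such steps. Across these four compounds, 2-fluorophenyl is the group that goes with the higher number, and none goes against this: a 4.6-fold lower number from compound 2 to compound 4 (0.66 log units; beyond the scatter) repeats, at a similar size, the step seen on the other core: the same change on two cores in this assay, a 6.0-fold higher number (0.78 log units; beyond the scatter) from compound 1 to compound 3 and a 4.6-fold higher number (0.66 log units; beyond the scatter) from compound 4 to compound 2, 1.3-fold (0.12 log units) apart, within the scatter of two such steps.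

The compounds shown leave open how a plain phenyl, or a phenyl ring carrying an amine or a carboxylic acid, would behave at this position. They also give no reason why 3-nitrophenyl and 3,4,5-trimethoxyphenyl, two quite different groups, end up within the scatter of each other.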